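A Longer Chain Against an Assay Limit

This account rests on a few compounds, and the source may have more. Where it says the series, first, only, none or still open, it means among the compounds named here.

In an ADME assay on Vero cells (Chlorocebus sabaeus) for cytotoxicity (a lower number here means a stronger inhibitor, a higher number a weaker inhibitor), compound 2 (`CCCCCCCCCCCC(=O)c1cc(O)c(O)c(O)c1`) gives > 1000 nM as a limit and not as a number. Compound 1 (`CCCCCCC(=O)c1cc(O)c(O)c(O)c1`) gives > 1000 nM as a limit too. Compound 3 (`CCCCCCCCCCCCC(=O)c1cc(O)c(O)c(O)c1`) gives > 1000 nM as a limit as well. Going by the values given here, the whole series so far therefore comes down to one reading: the limit of > 1000 nM in this assay, at which 3 of the 3 values shown sit, and no true number.

Compound 4 (`CCCCCCCCCCCCCCC(=O)c1cc(O)c(O)c(O)c1`) extends the chain of compound 2, with propyl in place of hydrogen on a saturated chain carbon, ten or more bonds along the chain from a carbonyl carbon sums up the change.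

The closest guide is a step that the two limits leave unreadable from compound 2 to compound 3 with methyl entering at the same kind of place. The other two changes, a step that the two limits leave unreadable from compound 1 to compound 2 and a step that the two limits leave unreadable from compound 1 to compound 3 give no size either. None of them offers a direction to carry forward.

In this assay the estimated outcome is a step that the limit leaves unreadable from compound 2 to compound 4 with no firm direction, and another limit is the likeliest report. For compound 4 the estimated value is 2000 nM with an expected range from 1000 nM to 10000 nM for any number that appears.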

Compound 4, half-maximal inhibitory concentration: > 1000 nM
Compound 4 ended at the assay's limit; the forecaster's own chance of this, stated with the estimate: 85%; the middle value lies beyond the limit too.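

Compound 4, like compound 1, compound 2 and compound 3, stands only as a limit in this assay, so no step among these compounds can be read: the limit of > 1000 nM in this assay, at which 4 of the 4 values shown sit.

From the compounds shown here alone, what stays open is whether any of these chain lengths would give a true number, and how the true values of the four compounds compare.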